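A few compounds are considered here, and "the series" means these few. Any claim that something is new, unique, unknown or untested is made for them only; others in the source may bear on it.

Measured so far in a functional assay on A-375 cells (Homo sapiens) for antiproliferative activity, read by trypan blue exclusion, with a stated time of 48 h, tested at 1 uM; on this read-out higher numbers stand for a weaker effect at the one concentration tested and lower numbers for a stronger effect:
- compound 1, `CCCCC#Cc1ccc(S(=O)(=O)Nc2cccc(-c3csc(NC(C)=O)n3)c2)cc1`: 73.2%
- compound 2, `CC(=O)Nc1nc(-c2cccc(NS(=O)(=O)c3ccc(C#CC4CCCCC4)cc3)c2)cs1`: 52.3%
- compound 3, `C#Cc1ccc(S(=O)(=O)Nc2cccc(-c3csc(NC(C)=O)n3)c2)cc1`: 59.2%

Compound 3 stands second highest of the three numbers. Going by the values given here, the step of a number 6.9 percentage points higher from compound 2 to compound 3 (within the scatter) is within the scatter, so compound 2 and compound 3 cannot be ordered; the step of a number 14 percentage points lower from compound 1 to compound 3 (beyond the scatter) is beyond it, so compound 1 is the one clearly weaker member of the set.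

Compound 4, `CC(=O)Nc1nc(-c2cccc(NS(=O)(=O)c3ccc(C#CCCc4ccccc4)cc3)c2)cs1`, has not been measured. It differs from compound 3 by phenethyl in place of hydrogen on a triple-bonded carbon. Among the compounds with values here, two measured steps touch the same triple-bonded carbon and bear on it. Read in reverse, a number 14 percentage points lower from compound 1 to compound 3 (beyond the scatter) says that putting butyl there raised the number by a modest amount, while a number 6.9 percentage points higher from compound 2 to compound 3 (within the scatter) says that cyclohexyl there made no difference beyond the scatter. Within the data shown here, a group on this carbon has thus gone either way, and phenethyl has no precedent. No direction is supported; the expected step of a number 0.8 percentage points higher from compound 3 to compound 4 (within the scatter) is therefore none beyond the scatter, with a modest change in either direction possible. Compound 4 is expected to give 60%, in the range 44% to 76%.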

Compound 4, a percentage reported as activity, at one concentration (the size of the read-out at that concentration, not a potency): 11.5%
Estimate against measurement, compound 4: 48.5 percentage points above; measured number below the stated range.
By their numbers in this assay, from the lowest: compound 4; then compounds 2 and 3 (each within the scatter of the next); then compound 1.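

In this assay, a group on the triple-bonded carbon can do far more than the butyl and cyclohexyl results indicated: a number 47.7 percentage points lower from compound 3 to compound 4 (beyond the scatter) and a number 40.8 percentage points lower from compound 2 to compound 4 (beyond the scatter) are both large. The step of a number 61.7 percentage points lower from compound 1 to compound 4 (beyond the scatter), with phenyl in place of ethyl on a saturated chain carbon, two bonds along the chain from a triple-bonded carbon, shows that the presence of a chain alone does not bring the low number, and that the phenyl goes with it. Nothing available here accounts for this result.

Open, on these data alone, is whether a phenyl directly on the triple-bonded carbon, a benzyl or a 3-phenylpropyl group gives a similar number, and whether a pyridyl ring or an amine in place of the phenyl does. The read-out at one concentration also gives no potency for compound 4.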